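Notes on the step from compound 2 to compound 3

This account rests on a few compounds, and the source may have more. Where it says the series, first, only, none or still open, it means among the compounds named here.

compound 1 `CCOC(=O)c1c(C)nc(-c2cccc(C#N)c2)n1OCc1ccc(Br)cc1`: 24600 nM
compound 2 `CCOC(=O)c1c(C)nc(-c2cccc(C#N)c2)n1OCc1ccccc1C#N`: 9380 nM

Both values come from a functional assay on a cell-free system (plasma, Oryctolagus cuniculus) for inhibition, with stated times of 5 min, 1 min and 6 min; a higher number here means a weaker inhibitor, a lower number a stronger inhibitor. Of the two measured compounds, compound 2 has the lower number, 9380 nM, and is the stronger inhibitor so far. Next in the series is compound 3 `CCOC(=O)c1c(C)nc(-c2cccc(C#N)c2)n1OCc1cccc(C#N)c1`, not yet measured. The change is 3-cyanophenyl in place of 2-cyanophenyl on a saturated chain carbon bound to an oxygen on an aromatic ring.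

Within the data shown here, only one measured step bears on this, a 2.6-fold lower number from compound 1 to compound 2 (0.42 log units; beyond the scatter). That step is modest, and it replaces 4-bromophenyl rather than moving the nitrile, so it gives only a rough guide to size and no direction for the new change. Among the measured compounds shown here, no measured compound carries 3-cyanophenyl. For the measured compounds named here, with compound 2 at the lowest number so far, 9380 nM, a small move to a higher number is expected, most likely within the scatter. In this assay the expected change is a 1.3-fold higher number from compound 2 to compound 3 (0.11 log units; within the scatter). The estimate for compound 3 is 12000 nM, with an expected range of 4500 nM to 30000 nM.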

Compound 3, half-maximal inhibitory concentration: > 30000 nM
Compound 3: a limit, no number; the forecaster's own chance of this, stated with the estimate: 8%; middle value at least 2.5-fold (0.39 log units) away from the limit.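

Compound 3 stands at a limit of this assay, not at a number: the limit of > 30000 nM in this assay, at which 1 of the 3 values shown sits.

Moving the nitrile, with the same atoms joined differently, gives an at least 3.1-fold higher number from compound 2 to compound 3 (0.50 log units; beyond the scatter), so 2-cyanophenyl and 3-cyanophenyl are not interchangeable on a saturated chain carbon bound to an oxygen on an aromatic ring. Replacing 4-bromophenyl gives an at least 1.2-fold higher number from compound 1 to compound 3 (0.08 log units; that floor lies within the scatter), so 3-cyanophenyl cannot be ordered against 4-bromophenyl beyond the scatter, while compound 2 keeps the lowest number of the three, with its steps to both others beyond the scatter.

As far as these compounds go, the size of the step to compound 3 stays open, as does any firm order between the 4-bromophenyl and 3-cyanophenyl compounds. Also open, from the compounds shown here alone, is whether the lower number of compound 2 depends on the nitrile itself or on any group at that ring position, a question that 2-chlorophenyl or 2-methoxyphenyl on the same carbon would address, while 4-cyanophenyl would complete the set of nitrile placements.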